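This account rests on a few compounds, and the source may have more. Where it says the series, first, only, none or still open, it means among the compounds named here.

Measured compounds:
compound 1 `Nc1scc(-c2ccccc2)c1C(=O)c1ccc(Cl)cc1`: 64%
compound 2 `Nc1scc(-c2cccc(Cl)c2)c1C(=O)c1ccc(Cl)cc1`: 75%

In a functional assay on CHO cells for agonist activity at adenosine receptor A1 (Homo sapiens), read by fluorescence and ERK phosphorylation, with stated times of 30 min and 1.5 h, tested at 10 uM (on this read-out lower numbers stand for a weaker effect and higher numbers for a stronger effect at the one concentration tested), compound 2 stands highest of the two numbers, with compound 1 the nearest and lower by a number 11 percentage points higher from compound 1 to compound 2 (beyond the scatter), a step that goes with chloro in place of hydrogen on an aromatic carbon. Compound 3 `Nc1scc(-c2ccc(Cl)cc2)c1C(=O)c1ccc(Cl)cc1` has not yet been measured in this assay. Compared with compound 2 it shows (4-chlorophenyl in place of 3-chlorophenyl on an aromatic carbon). For the measured compounds named here, no measured step rests on this change: the only step known, from compound 1 to compound 2, concerns the presence of the chlorine and not where it sits, so it does not bear directly on the move to compound 3. With nothing in the numbers pointing either way, the step from compound 2 to compound 3 is expected to be a number 3 percentage points lower from compound 2 to compound 3 (within the scatter), within the scatter. Compound 3 is therefore estimated at 72% in this assay, with a range from 50% to 90%.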

Compound 3, a percentage reported as activity, at one concentration (the size of the read-out at that concentration, not a potency): 50%
For compound 3 the middle estimate is 22 percentage points above the measured one; the range from low to high includes it.
By their numbers in this assay, from the lowest: compound 3; then compound 1; then compound 2.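

The chlorine's presence alone does not set the outcome in this assay: a move from 3-chlorophenyl to 4-chlorophenyl gives a number 25 percentage points lower from compound 2 to compound 3 (beyond the scatter) even though the two groups hold the same atoms. Against the unsubstituted phenyl, the 4-chlorophenyl group gives a number 14 percentage points lower from compound 1 to compound 3 (beyond the scatter) and so goes the opposite way to a number 11 percentage points higher from compound 1 to compound 2 (beyond the scatter), which means that the same chloro-for-hydrogen change can raise or lower the read-out at this position, depending on where the chlorine sits on the phenyl group. Nothing available explains this difference between the two chlorophenyl groups.

The compounds shown leave open whether a methoxy group, a bromine or an amine at these same phenyl carbons would follow the chlorine's pattern. They also leave open how these compounds compare at any other concentration: the read-out gives only a stronger or weaker effect at the one concentration tested.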